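The source may hold more compounds than are shown below. What is called first, only, known or untested is meant among the compounds shown, and "the series" means these compounds.

Of the compounds shown here, two built on a shared core have been measured in a functional assay on KB cells (Homo sapiens) for antiproliferative activity, read by sulforhodamine B assay, with a stated time of 3 days; a higher number here means that more compound is needed for the effect, a lower number that less compound is needed. Compound 1, `CCCC1=C(OCC(C)C)C(CCC)(CCC)C(=O)/C(=C(O)\C=C\c2ccccc2)C1=O`, gives 4.8 uM in this assay. Compound 2, `CCCC1=C(OC)C(CCC)(CCC)C(=O)/C(=C(O)\C=C\c2ccc(I)cc2)C1=O`, gives 1.5 uM in this assay. Of these two numbers, compound 2 holds the lower one, and the number for compound 1 is higher by a margin that lies beyond the usual scatter of repeated measurements of this kind.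

Compound 3, `CCCC1=C(OC)C(CCC)(CCC)C(=O)/C(=C(O)\C=C\c2ccc(Br)cc2)C1=O`, has not yet been measured. It differs from compound 2 in a single place: bromo in place of iodo on an aromatic carbon. Within the data shown here, no step between two measured compounds shows this kind of exchange, so nothing measured here sets its size. One halogen gives way to another on the same aromatic carbon, and a change of this kind is expected to move the number only a little. Compound 3 is therefore expected to give about 2 uM in this assay, with a range from 0.9 uM to 4.5 uM. The expected step of a 1.3-fold higher number from compound 2 to compound 3 (0.12 log units; within the scatter) is small, within or close to the usual scatter, and could fall in either direction.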

Compound 3, concentration for half-maximal effect: 1.8 uM
Estimate against measurement, compound 3: 1.1-fold (0.05 log units) above; low and high end bracket the measured number.
By their numbers in this assay, from the lowest: compounds 2 and 3 (each within the scatter of the next); then compound 1.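

In this assay, among these compounds, the exchange of 4-iodophenyl for 4-bromophenyl gives a 1.2-fold higher number from compound 2 to compound 3 (0.08 log units; within the scatter) and so offers the first direct reading of this aromatic carbon: these two halogens cannot be told apart here. Compounds 1 and 2 differ in more than one place, so their gap could not be tied to any single group, whereas this pair changes only one atom. No evidence is at hand on what lies behind the closeness of these two numbers.

On these data alone, it remains open whether a chloro, a fluoro, a methoxy group, an amine or a carboxylic acid on the same aromatic carbon would read like bromo and iodo, or would move the number beyond the scatter. Compound 1 has no halogen on its phenyl ring but also differs from compound 2 in a second place on the shared core, so what a halogen at this carbon contributes at all, compared with plain hydrogen, stays unread.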